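The source may hold more compounds than are shown below. What is called first, only, known or untested is meant among the compounds shown, and "the series" means these compounds.

Of the compounds shown here, two that share one core have been measured in an assay on isolated protein for agonist activity at Bile acid receptor (Homo sapiens), read by AlphaScreen, with a stated time of 30 min; a lower number here means that less compound is needed, a higher number that more compound is needed for the effect. Compound 1 `COc1ccccc1-c1ccc([C@H]2S[C@@H](C)C(=O)Nc3c2c(C)nn3-c2ccccc2C)cc1` gives 1100 nM. Compound 2 `Cc1ccccc1-n1nc(C)c2c1NC(=O)[C@H](C)S[C@@H]2c1ccc(-c2ccco2)cc1` gives 3600 nM, the highest of the two numbers; its nearest neighbour is compound 1, and the step of a 3.3-fold higher number from compound 1 to compound 2 (0.51 log units; beyond the scatter) comes from putting furan-2-yl in place of 2-methoxyphenyl on an aromatic carbon. The unmeasured compound 3 `Cc1ccccc1-n1nc(C)c2c1NC(=O)[C@H](C)S[C@@H]2c1ccc(Oc2cccc(C(=O)O)c2)cc1` differs from compound 2 in one place: 3-carboxyphenoxy in place of furan-2-yl on an aromatic carbon. The new group sits on an aromatic carbon of a six-membered aromatic ring of carbon only, para to a large group. For the measured compounds named here, no measured step involves 3-carboxyphenoxy, so nothing seen so far points to a direction. Going by the values given here, the single step in hand, from compound 1 to compound 2, shows only that exchanging the group at this position moved this assay by a modest amount, so a change of similar size, in either direction, is the most that can reasonably be expected. The estimate for compound 3 in this assay is therefore 2000 nM, within 400 nM to 10000 nM, an expected step of a 1.8-fold lower number from compound 2 to compound 3 (0.26 log units; within the scatter).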

Compound 3, half-maximal effective concentration: "not active" (no number reported)
The entry for compound 3 holds no number; the estimate stays without a comparison.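

In this assay, for the compounds shown here, compound 3 is reported as not active, with no number, so no step from compound 2 to compound 3 can be read. Nothing available bears on this result. The compounds shown leave open how other groups at this place on the shared core would compare with furan-2-yl and 2-methoxyphenyl.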